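The source may report more compounds than this note shows. Statements on the series, on what has been measured and on what is new or still open speak of the compounds shown alone.

Measured so far in an assay on isolated protein for inhibition of myosin-2 (Bos taurus), read by spectrophotometry, with a stated time of 24 min; a lower number here means a stronger inhibitor, a higher number a weaker inhibitor:
compound 1 `C/C(=N\CCO)c1c(O)c2ccccc2oc1=O` gives 92000 nM;
compound 2 `C/C(=N\Cc1cccc(C)c1)c1c(O)c2ccccc2oc1=O` gives 4900 nM;
compound 3 `CCCCCC/N=C(\C)c1c(O)c2ccccc2oc1=O` gives 2900 nM.

Compound 3 has the lowest number of the three, but its gap to compound 2 lies within the scatter, so only compound 1 stands clearly apart. Compound 4 `C/C(=N\Cc1ccc(C)cc1)c1c(O)c2ccccc2oc1=O` differs from compound 3 by 4-methylphenyl in place of pentyl on a saturated chain carbon bound to a double-bonded nitrogen. The step that bears directly on this is a 1.7-fold lower number from compound 2 to compound 3 (0.23 log units; within the scatter), where a methylphenyl group and a pentyl chain gave numbers within the scatter of each other. The large steps of a 19-fold lower number from compound 1 to compound 2 (1.27 log units; beyond the scatter) and a 32-fold lower number from compound 1 to compound 3 (1.50 log units; beyond the scatter) show both kinds of group acting alike. Compound 4 is therefore expected to show a 1.6-fold higher number from compound 3 to compound 4 (0.19 log units; within the scatter), a shift within the scatter. In this assay compound 4 is estimated at 4500 nM, between 2000 nM and 10000 nM.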

Compound 4, half-maximal inhibitory concentration: 7900 nM
Estimate against measurement, compound 4: 1.8-fold (0.24 log units) below; measured number inside the range.
By their numbers in this assay, from the lowest: compounds 3, 2 and 4 (each within the scatter of the next, the first and the last beyond it); then compound 1.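

In this assay, an aromatic ring and a straight chain at this position no longer look interchangeable: 4-methylphenyl in place of pentyl gives a 2.7-fold higher number from compound 3 to compound 4 (0.44 log units; beyond the scatter). Changing 3-methylphenyl to 4-methylphenyl gives a 1.6-fold higher number from compound 2 to compound 4 (0.21 log units; within the scatter), so the two methylphenyl groups cannot be told apart here. The large gain over hydroxymethyl also holds for this new group, with a 12-fold lower number from compound 1 to compound 4 (1.07 log units; beyond the scatter). Still open, from the compounds shown here alone, is how a longer chain, an unsubstituted phenyl or an amine at the end of the chain would compare. Nothing available gives a reason for these steps.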